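This account rests on a few compounds, and the source may have more. Where it says the series, first, only, none or still open, it means among the compounds named here.

Measured so far:
compound 1, `Nc1nc(Cl)c2ncn(Cc3ccccc3CCl)c2n1`: 3890 nM
compound 2, `ClCc1cccc(Cn2cnc3nc(Cl)nc(Cl)c32)c1`: 340 nM

In a functional assay on HT-29 cells (Homo sapiens) for cytotoxicity, read by sulforhodamine B assay, with a stated time of 48 h (on this read-out lower numbers stand for stronger inhibition of growth and higher numbers for weaker inhibition of growth), compound 1 holds the highest of the two numbers; the nearest is compound 2, which sits well below it, a gap beyond the scatter.

Compound 3, `ClCc1ccccc1Cn1cnc2c(Cl)ncnc21`, is not yet measured. It differs from compound 1 by hydrogen in place of amino on an aromatic carbon. Among the measured compounds shown here, no pair of measured compounds covers this change, so the expectation rests on compound 1 alone. Compound 3 is estimated at 2500 nM (range 600 nM to 10000 nM), meaning an expected step of a 1.6-fold lower number from compound 1 to compound 3 (0.19 log units; within the scatter) toward lower numbers, one that may not clear the scatter.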

Compound 3, concentration for 50% growth inhibition: 3540 nM
Compound 3: the middle estimate sits 1.4-fold (0.15 log units) below what was measured, within the range that was stated.
By their numbers in this assay, from the lowest: compound 2; then compounds 3 and 1 (each within the scatter of the next).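

In this assay, amino on the aromatic carbon between two ring nitrogen atoms can give way to hydrogen without a readable change (a 1.1-fold lower number from compound 1 to compound 3 (0.04 log units; within the scatter)). On this core, with the rest of compound 1 unchanged, growth inhibition therefore does not depend on the amino group. No measurement at hand accounts for this result.

On these data alone, whether a methylamino or methoxy group at this position would move the number stays open. Compound 2 differs from compound 1 and compound 3 in more than one place, so its number cannot be assigned to any single change.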